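The source may report more compounds than this note shows. Statements on the series, on what has been measured and on what is new or still open speak of the compounds shown alone.

In an assay on isolated protein (Oryctolagus cuniculus) with Thromboxane-A synthase (Homo sapiens) as the target, tested at 1 uM (a higher number here means more inhibition at the concentration tested (going by the name of the read-out), a lower number less inhibition), compound 1 `C=CCn1nc(-c2cccnc2)c2ccccc2c1=O` gives 70%, compound 2 `O=c1c2ccccc2c(-c2cccnc2)nn1Cc1cccc(Cl)c1` gives 95%, and compound 3 `O=C(O)Cn1nc(-c2cccnc2)c2ccccc2c1=O` gives 13%. Compound 3 thus stands lowest of the three: the step of a number 57 percentage points lower from compound 1 to compound 3 (beyond the scatter) and the step of a number 82 percentage points lower from compound 2 to compound 3 (beyond the scatter) both run downward into it, while the step of a number 25 percentage points higher from compound 1 to compound 2 (beyond the scatter) is the only one that climbs. Compound 4 `CC(C)NC(=O)CCCn1nc(-c2cccnc2)c2ccccc2c1=O` is not yet measured; it differs from compound 3 in one place, (2-(isopropylcarbamoyl)ethyl in place of carboxy on a saturated chain carbon bound to an aromatic nitrogen). The two steps that bear on this change are those in which carboxy entered on the same saturated chain carbon, and both were large losses in this assay. Since in compound 4 carboxy leaves again and a chain group without the carboxy enters, a large rise in this assay is expected, back toward the level of compound 1. For compound 4 the expected step is a number 52 percentage points higher from compound 3 to compound 4 (beyond the scatter). Compound 4 is estimated at 65%, with a range from 35% to 90%.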

Compound 4, a percentage reported as inhibition, at one concentration (the size of the read-out at that concentration, not a potency): 89%
Estimate against measurement, compound 4: 24 percentage points below; measured number inside the range.
By their numbers in this assay, from the lowest: compound 3; then compound 1; then compounds 4 and 2 (each within the scatter of the next).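

In this assay, the step of a number 76 percentage points higher from compound 3 to compound 4 (beyond the scatter) shows that the low number of compound 3 does not follow from the counts alone: carboxy and 2-(isopropylcarbamoyl)ethyl both have one hydrogen-bond donor, one hydrogen-bond acceptor and no net charge, yet only the second gives a high number on this saturated chain carbon. The step of a number 19 percentage points higher from compound 1 to compound 4 (beyond the scatter) and the step of a number 6 percentage points lower from compound 2 to compound 4 (within the scatter) show that a chain group with no ring can exceed vinyl at this position and stand level with 3-chlorophenyl, so a ring is not needed here for a high number.

From the compounds shown here alone, whether the amide or the chain itself carries this gain stays open, and a plain butyl chain, an ester or an amine at the chain end could separate the two. Nothing measured here explains the differences between these groups.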